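Ester, amide and hydrazide on a shared core: compound 4

A few compounds are considered here, and "the series" means these few. Any claim that something is new, unique, unknown or untested is made for them only; others in the source may bear on it.

Measured so far:
Compound 1 `NC(=O)c1nc(-c2ccccc2)n(-c2ccc(S(N)(=O)=O)cc2)n1` — 52%
Compound 2 `NNC(=O)c1nc(-c2ccccc2)n(-c2ccc(S(N)(=O)=O)cc2)n1` — 60%
Compound 3 `COC(=O)c1nc(-c2ccccc2)n(-c2ccc(S(N)(=O)=O)cc2)n1` — 69%

All three were read in a functional assay on the whole organism for inhibition, with Rattus norvegicus as the target, read by paw edema, with stated times of 30 min and 3 h, at a dose of 0.28 mmol/kg by the oral route; a lower number here means less inhibition, a higher number more inhibition at the dose given (going by the name of the read-out). Compound 3 gives the highest number of the three with 69%; one gap is a number 9 percentage points higher from compound 2 to compound 3 (within the scatter), so those two cannot be ordered, while the other, a number 17 percentage points higher from compound 1 to compound 3 (beyond the scatter), is a modest step beyond the scatter.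

Compound 4 `CC(C)NC(=O)c1nc(-c2ccccc2)n(-c2ccc(S(N)(=O)=O)cc2)n1` is not yet measured. Its difference from compound 3 is isopropylamino in place of methoxy on a carbonyl carbon. For the measured compounds named here, the change on the carbonyl carbon returns to an amide-type group, so the steps that bear on it are the ones in which the carbonyl substituent was varied: a number 17 percentage points higher from compound 1 to compound 3 (beyond the scatter) and a number 9 percentage points higher from compound 2 to compound 3 (within the scatter). Both run towards the methoxy group, the first beyond the scatter, the second within it. Going the other way, a drop in this assay of about the size seen for compound 1 is the most likely outcome; the hydrazide of compound 2 shows the drop need not clear the scatter.

For compound 4 the expected value in this assay is therefore 57%, with a range of 44% to 70%, which means an expected step of a number 12 percentage points lower from compound 3 to compound 4 (beyond the scatter).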

Compound 4, a percentage reported as inhibition, in the whole organism at one dose (the size of the read-out at that dose, not a potency): 55%
Beside the measured number, compound 4's estimate is 2 percentage points above it, within the range that was stated.
By their numbers in this assay, from the lowest: compounds 1, 4, 2 and 3 (each within the scatter of the next, the first and the last beyond it).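

In this assay, the step from methoxy to isopropylamino on the carbonyl carbon reads a number 14 percentage points lower from compound 3 to compound 4 (beyond the scatter), so a substituted amide also falls beyond the scatter from the methoxy compound, which the unsubstituted amide of compound 1 had already shown. On the amide-type nitrogen, the change to isopropyl gives a number 3 percentage points higher from compound 1 to compound 4 (within the scatter) from hydrogen and a number 5 percentage points lower from compound 2 to compound 4 (within the scatter) from amino, so the group on that nitrogen has no readable effect in this set, even with a group as large as isopropyl. The separation of methoxy from the nitrogen-linked groups is incomplete, with compound 2 going against it, and no measurement here accounts for the gap that is seen.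

As far as these compounds go, whether a carboxylic acid or an ethoxy group on the carbonyl carbon would read like methoxy or like the nitrogen-linked groups stays open, as does the effect of a longer chain such as n-butyl on the amide-type nitrogen. Piperidine joined through its nitrogen to the carbonyl carbon would leave no amide hydrogen, and would show whether that hydrogen goes with the numbers of compound 1 and compound 4.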